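A Cyano Group Gives Way to a Sulfur Ring

This account rests on a few compounds, and the source may have more. Where it says the series, first, only, none or still open, it means among the compounds named here.

Compound 1, `O=C1OC(C(O)Cn2ccc(=O)[nH]c2=O)C(OCc2ccccc2)=C1OCc1ccccc1`, gives 157000 nM in an ADME assay on L1210/0 cells (Mus musculus) for cytotoxicity, with a stated time of 48 h; on this read-out higher numbers stand for weaker inhibition and lower numbers for stronger inhibition.
Compound 2, `C[C@@]1(CO)O[C@H](c2ccc(N)cc2F)C[C@@H]1O`, reaches only the limit of this assay, > 200000 nM.
Compound 3, `N#Cc1cn([C@H]2C[C@H](O)[C@@H](CO)O2)c(=O)[nH]c1=O`, likewise reaches only the limit of this assay, > 200000 nM.

Compound 3 therefore stands at the edge of what this assay can report: its result is a limit, not a number, and it is not alone there, since (the limit of > 200000 nM in this assay, at which 2 of the 3 values shown sit). Only compound 1 gives an actual value, and that value is itself weak.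

Compound 4, `O=c1[nH]c(=O)n([C@H]2C[C@H](O)[C@@H](CO)O2)cc1C1SCCS1`, is not yet measured. It differs from compound 3 in one place: a group of 5 heavy atoms (3 carbon, 2 sulfur; one five-membered non-aromatic ring with 2 hetero atoms) in place of a group of 2 heavy atoms (1 carbon, 1 nitrogen; no ring), on an aromatic carbon. The cyano group on the aromatic carbon is replaced by the ring of three carbons and two sulfurs, while the rest of the molecule is kept.

Among the compounds with values here, no step between two measured compounds is available here, so there is nothing to calibrate this change against. With two of three values sitting at the limit and the third weak, the expected step in this assay is none beyond the scatter, and compound 4 is expected to sit at or near the limit as well. Compound 4 is expected at 200000 nM, within 60000 nM to 600000 nM. The expected step of a number no higher from compound 3 to compound 4 (the limit leaves the size open) is, in other words, essentially flat.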

Compound 4, half-maximal inhibitory concentration: > 200000 nM
Compound 4: a limit, no number; the forecaster's own chance of this, stated with the estimate: 70%; the middle value lies on the limit itself.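

In this assay compound 4 gives > 200000 nM, which is a limit and not a number. Compound 3 also sits at a limit, so no step can be read from compound 3 to compound 4. The compounds shown leave open whether replacing the cyano group with the sulfur ring changes the read-out at all.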